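A few compounds are considered here, and "the series" means these few. Any claim that something is new, unique, unknown or untested is made for them only; others in the source may bear on it.

Measured compounds, all in a functional assay on B16-F10 cells (Mus musculus) for antiproliferative activity, read by MTT assay, with a stated time of 48 h; a higher number here means a weaker inhibitor, a lower number a stronger inhibitor:
- compound 1 `COc1ccc(-c2csc(N3N=C(c4ccc(C)cc4)CC3c3ccc4c(c3)OCCO4)n2)cc1` gives 2870 nM
- compound 2 `COc1ccc(-c2csc(N3N=C(c4ccc(F)cc4)CC3c3ccc4c(c3)OCCO4)n2)cc1` gives 4430 nM
- compound 3 `COc1ccc(C2=NN(c3nc(-c4ccc(OC)cc4)cs3)C(c3ccc4c(c3)OCCO4)C2)cc1` gives 3010 nM

The three compounds share one core and differ only in the group on an aromatic carbon of a six-membered aromatic ring of carbon only. Compound 3 carries the methoxy there, and in this assay its number sits between those of the other two, yet every gap is within the scatter: the step of a 1.0-fold higher number from compound 1 to compound 3 (0.02 log units; within the scatter) and the step of a 1.5-fold lower number from compound 2 to compound 3 (0.17 log units; within the scatter) are both small enough to count as no change.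

Compound 4 `COc1ccc(-c2csc(N3N=C(c4ccc(Br)cc4)CC3c3ccc4c(c3)OCCO4)n2)cc1` is the next member: bromo in place of methoxy on an aromatic carbon. For the measured compounds named here, no measured step involves bromo, so the closest guides are the halogen steps already seen, a 1.5-fold higher number from compound 1 to compound 2 (0.19 log units; within the scatter) and a 1.5-fold lower number from compound 2 to compound 3 (0.17 log units; within the scatter), neither of which rose above the scatter. On that basis compound 4 is expected to land near compound 3, with a step of a 1.2-fold higher number from compound 3 to compound 4 (0.07 log units; within the scatter) that stays inside the usual spread, and its estimated value is 3500 nM, within a range from 1500 nM to 8000 nM.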

Compound 4, half-maximal inhibitory concentration: 1120 nM
For compound 4 the middle estimate is 3.1-fold (0.49 log units) above the measured one, and the stated range ends above it.
By their numbers in this assay, from the lowest: compound 4; then compounds 1, 3 and 2 (each within the scatter of the next).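

In this assay, for the compounds shown here, the methyl, fluoro and methoxy compounds stay within the scatter of one another, so this aromatic carbon looked insensitive to its group; bromo is the first group to move the number beyond the scatter, with a 2.7-fold lower number from compound 3 to compound 4 (0.43 log units; beyond the scatter) and a 2.6-fold lower number from compound 1 to compound 4 (0.41 log units; beyond the scatter) as the two steps from those neighbours. The two halogens also part ways, as a 4.0-fold lower number from compound 2 to compound 4 (0.60 log units; beyond the scatter) is the largest of the new steps, so carrying a halogen at this position is not enough by itself, and compound 4 is the strongest inhibitor of the four. Nothing available here explains why bromo stands apart. On these data alone, it remains open whether this gain belongs to bromo alone or would also appear with chloro, iodo or trifluoromethyl at the same position. As far as these compounds go, how an amine or a carboxylic acid would behave there is equally open.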